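A few compounds are considered here, and "the series" means these few. Any claim that something is new, unique, unknown or untested is made for them only; others in the source may bear on it.

Measured so far:

Compound 1, `COc1ccc(C(c2ccccc2O)c2cccc3ccccc23)c(OC)c1OC`, gives 17700 nM.
Compound 2, `COc1ccc(C(O)(Cc2ccc(F)cc2)c2cccc3ccccc23)c(OC)c1OC`, gives 5440 nM.
Compound 3, `COc1ccc(/C(=N/O)c2cccc3ccccc23)c(OC)c1OC`, gives 2500 nM.

These three compounds share a core and were tested in a functional assay on MDA-MB-231 cells (Homo sapiens) for inhibition, read by sulforhodamine B assay, with a stated time of 48 h; a higher number here means a weaker inhibitor, a lower number a stronger inhibitor. On the three numbers shown, compound 2 stands second highest: its nearest neighbour is compound 3, whose number is lower by more than the scatter, and its furthest is compound 1, whose number is higher by more than the scatter. Going by the values given here, no pair among the measured compounds differs in only one place, so no single step can be read off directly from them.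

Compound 4, `COc1ccc(C(O)(Cc2ccc(C)cc2)c2cccc3ccccc23)c(OC)c1OC`, has not yet been measured in this assay. It differs from compound 2 in one place: methyl in place of fluoro on an aromatic carbon. The fluoro leaves and the methyl enters, each a single heavy atom without ring, donor, acceptor or charge, on an aromatic carbon para to a large group.

Among the compounds with values here, with no measured step of this kind to lean on, the expectation is a small change from compound 2 to compound 4, a 1.1-fold lower number from compound 2 to compound 4 (0.04 log units; within the scatter), in either direction and not beyond the scatter. Compound 4 is therefore estimated at 5000 nM, with a range from 2000 nM to 13000 nM.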

Compound 4, half-maximal inhibitory concentration: > 20000 nM
Compound 4 gave a limit, no number (the forecaster's own chance of this, stated with the estimate: 3%); middle value at least 4.0-fold (0.60 log units) away from the limit.
By their numbers in this assay, from the lowest: compound 3; then compound 2; then compound 1. At a limit, above all of these: compound 4.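

Going by these compounds alone, this is the first step in the set that changes only one place, and it shows that the group at this position matters: replacing fluoro with methyl on an aromatic carbon, para to a large group, gives an at least 3.6-fold higher number from compound 2 to compound 4 (0.56 log units; beyond the scatter). In this assay, on these data alone, compound 4 gives > 20000 nM, which is a limit of the assay and not a number: the limit of > 20000 nM in this assay, at which 1 of the 4 values shown sits. The true size of the step therefore remains unknown, but even its printed minimum shows that exchanging one single heavy atom for another, with no ring, donor, acceptor or charge entering or leaving, can separate two otherwise identical compounds by more than the usual scatter.

As far as these compounds go, with only fluoro and methyl compared at this position, it remains open how a plain hydrogen, chloro, methoxy or an amine in the same place would read, and whether any of them would match or improve on compound 2. Also open, from the compounds shown here alone, is whether methyl in place of fluoro would have a similar effect on a different core.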